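Ester branching and furan attachment in a small series

The source may hold more compounds than are shown below. What is called first, only, known or untested is meant among the compounds shown, and "the series" means these compounds.

The series rests on a shared core carrying an ester and a furan, with only these two parts varied. Compound 1 `CC1=C(C(=O)OCC(C)C)C(c2ccco2)NC(=O)N1C` serves as the reference point; in an assay on membranes from CHO cells for displacement of a labelled ligand from adenosine receptor A1 (Homo sapiens), read by scintillation counting, with a stated time of 60 min, tested at 1 uM (a higher number here means more inhibition at the concentration tested (going by the name of the read-out), a lower number less inhibition), compound 1 gives 13%. Compound 2 `CC1=C(C(=O)OC(C)(C)C)C(c2ccco2)NC(=O)N1C` differs from compound 1 by tert-butyl in place of isobutyl on an oxygen next to a carbonyl group, and in this assay compound 2 gives 44%, a step of a number 31 percentage points higher from compound 1 to compound 2 (beyond the scatter). Compound 3 `CC1=C(C(=O)OCC(C)C)C(c2ccoc2)NC(=O)N1C` differs from compound 1 in the core by furan-3-yl in place of furan-2-yl on a saturated ring carbon; in this assay compound 3 gives 4%, a step of a number 9 percentage points lower from compound 1 to compound 3 (within the scatter). Among the three measured compounds, compound 3 has the lowest number, though its gap to compound 1 lies within the scatter.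

Compound 4 `CC1=C(C(=O)OC(C)(C)C)C(c2ccoc2)NC(=O)N1C` has not been measured. It differs from compound 3 by tert-butyl in place of isobutyl on an oxygen next to a carbonyl group, the same change that took compound 1 to compound 2, made at the same place. Within the data shown here, the one measured instance of this change is the step from compound 1 to compound 2. Nothing shows whether the change behaves the same on the core of compound 3, and a single pair gives no pattern to lean on.

For compound 4 the step in this assay is expected to be a number 26 percentage points higher from compound 3 to compound 4 (beyond the scatter), somewhat smaller than the earlier one, because the same change gave a number 31 percentage points higher from compound 1 to compound 2 (beyond the scatter) while compound 3 starts lower. Compound 4 is therefore estimated to give 30%, with a likely range from 10% to 50%.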

Compound 4, a percentage reported as inhibition, at one concentration (the size of the read-out at that concentration, not a potency): 21%
Compound 4: middle estimate off by 9 percentage points, on the high side, and the stated range covers the measured number.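

In this assay, tert-butyl in place of isobutyl on the oxygen next to the carbonyl group again gives a higher number with furan-3-yl in the molecule, a number 17 percentage points higher from compound 3 to compound 4 (beyond the scatter), so the change carries over from the core of compound 1 to the core of compound 3 in direction, and the two steps cannot be told apart in size: the same change on two cores in this assay, a number 31 percentage points higher (beyond the scatter) from compound 1 to compound 2 and a number 17 percentage points higher (beyond the scatter) from compound 3 to compound 4, 14 percentage points apart, within the scatter of two such steps

Read the other way, furan-3-yl in place of furan-2-yl gives a number 23 percentage points lower from compound 2 to compound 4 (beyond the scatter), which clears the scatter, whereas the same change with the isobutyl ester does not, and this contrast is not a measured difference between the two steps: the same change on two cores in this assay, a number 9 percentage points lower (within the scatter) from compound 1 to compound 3 and a number 23 percentage points lower (beyond the scatter) from compound 2 to compound 4, 14 percentage points apart, within the scatter of two such steps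

This is one set of four compounds in one assay at one concentration, so it shows that the ester change held across two cores, but not that it would hold on any further core, and it gives no potency for any of the four.

The compounds shown leave open whether a longer chain on the ester oxygen would continue the trend seen with tert-butyl, and whether a carboxylic acid in place of the ester would keep any of the inhibition. They also leave open how an amine on the saturated ring carbon, in place of either furan, would read in this assay.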